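Halogen swap on the fused aromatic ring of compound 3

The compounds below may be only part of what the source reports. "The series", "measured", "known", "first", "only" and "open" are said of these compounds alone.

Measured so far:
compound 1 `COC(=O)[C@@]1(C)CCC=C2[C@@H]1CC[C@@H](C)[C@]2(C)Cc1c[nH]c2ccc(F)cc12` 3900 nM
compound 2 `COC(=O)[C@@]1(C)CCC=C2[C@@H]1CC[C@@H](C)[C@]2(C)Cc1c(C)[nH]c2ccccc12` 17000 nM
compound 3 `COC(=O)[C@@]1(C)CCC=C2[C@@H]1CC[C@@H](C)[C@]2(C)Cc1c(C)[nH]c2ccc(Cl)cc12` 17000 nM

In a functional assay on T47D cells (Homo sapiens) for inhibition, read by sulforhodamine B assay, with a stated time of 48 h (a higher number here means a weaker inhibitor of growth, a lower number a stronger inhibitor of growth), compound 3 stands level with compound 2, the two together giving the highest numbers of the three. Compound 1 sits furthest away, with a lower number, and that gap is beyond the scatter; compound 1 differs from compound 3 in more than one place, so nothing more is read from it here.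

Compound 4 `COC(=O)[C@@]1(C)CCC=C2[C@@H]1CC[C@@H](C)[C@]2(C)Cc1c(C)[nH]c2ccc(F)cc12` is the next member. It differs from compound 3 by fluoro in place of chloro on an aromatic carbon. Going by the values given here, the one measured step at this position, no change at the digits printed from compound 2 to compound 3 (within the scatter), exchanged hydrogen for chloro and moved nothing beyond the scatter. Chloro and fluoro are both single-atom halogens on the same carbon, and the series so far gives no sign that this carbon is sensitive to what sits on it.

The expectation is therefore no step beyond the scatter: a 1.1-fold lower number from compound 3 to compound 4 (0.05 log units; within the scatter) is estimated to be flat. Compound 4 is expected at 15000 nM in this assay, within a range of 6000 nM to 40000 nM.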

Compound 4, concentration for 50% growth inhibition: 15000 nM
Estimate against measurement, compound 4: no gap at the digits printed; low and high end bracket the measured number.
By their numbers in this assay, from the lowest: compound 1; then compounds 4, 2 and 3 (each within the scatter of the next).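

In this assay, exchanging one halogen for the other gives a 1.1-fold lower number from compound 3 to compound 4 (0.05 log units; within the scatter), and the fluoro compound set against the unsubstituted ring gives a 1.1-fold lower number from compound 2 to compound 4 (0.05 log units; within the scatter), so hydrogen, chloro and fluoro on this aromatic carbon now form a complete set of three that cannot be told apart in this series with the methyl group present. Going by these compounds alone, compound 4 also provides the first single-place comparison with compound 1, a 3.8-fold higher number from compound 1 to compound 4 (0.59 log units; beyond the scatter), which is beyond the scatter and ties the separation of compound 1 to methyl in place of hydrogen on the other aromatic carbon, not to the halogen position. No measurement at hand explains the flat response at one position or the step at the other.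

As far as these compounds go, whether the flat response extends past hydrogen and the two halogens, for example to an amine, a carboxylic acid or a methoxy group on the same carbon, stays open. The methyl step also rests on a single pair carrying fluoro, so whether it holds with chloro or hydrogen on the aromatic ring is unresolved.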